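The source may report more compounds than this note shows. Statements on the series, on what has been measured and on what is new or still open speak of the compounds shown alone.

Compound 1, with the structure `CCC1(O)CS(=O)(=O)c2cc(C(=O)N=C(N)N)c(C)cc21`, is measured in an assay on cells for inhibition of sodium/hydrogen exchanger (Oryctolagus cuniculus) (a higher number here means a weaker inhibitor, a lower number a stronger inhibitor), where compound 1 gives 34 nM. Compound 2, `CCC1CS(=O)(=O)c2cc(C(=O)N=C(N)N)c(C)cc21`, keeps the core of compound 1 but carries the change (hydrogen in place of hydroxy on a saturated ring carbon); in this assay compound 2 gives 24 nM, and the step of a 1.4-fold lower number from compound 1 to compound 2 (0.15 log units; within the scatter) is small. Compound 3, `N=C(N)NC(=O)c1ccc2c(c1)S(=O)(=O)CC2O`, rests on a different core, and the difference between the two cores is not broken down here. In this assay compound 3 gives 1500 nM, the highest of the three numbers and well beyond the scatter from both compound 1 and compound 2. Compound 4, `N=C(N)NC(=O)c1ccc2c(c1)S(=O)(=O)CC2`, is not yet measured; it derives from compound 3 by the change (hydrogen in place of hydroxy on a saturated ring carbon), which is the same change that separates compound 1 from compound 2, at the same kind of place. The step from compound 3 to compound 4 in this assay is expected to be about a 1.4-fold lower number from compound 3 to compound 4 (0.13 log units; within the scatter), because the matching step a 1.4-fold lower number from compound 1 to compound 2 (0.15 log units; within the scatter) stayed within the scatter. Compound 4 is therefore estimated at 1100 nM, with a range from 400 nM to 3000 nM.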

Compound 4, half-maximal inhibitory concentration: 790 nM
Estimate against measurement, compound 4: 1.4-fold (0.14 log units) above; the measured number falls inside the stated range.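

In this assay, putting hydrogen in place of hydroxy on the saturated ring carbon gives a 1.9-fold lower number from compound 3 to compound 4 (0.28 log units; within the scatter), so on this second core the change again stays within the scatter. Set beside the same change on the core of compound 1, the two steps agree: the same change on two cores in this assay, a 1.4-fold lower number (0.15 log units; within the scatter) from compound 1 to compound 2 and a 1.9-fold lower number (0.28 log units; within the scatter) from compound 3 to compound 4, 1.3-fold (0.13 log units) apart, within the scatter of two such steps. This shows that, across these two pairs, the change carried from one core to the other without a step that can be told from the scatter, but it does not show that it would do so on any further core, nor does it give the change a reliable direction. The two cores differ in more than one place, and the data do not break down the gap between them.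

The compounds shown leave open what a methoxy group, an amine or a fluorine atom would do in place of the hydroxy on that ring carbon. They also leave open how much of the gap between the cores belongs to the ethyl group and how much to the methyl group.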